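The compounds below may be only part of what the source reports. "The series", "measured", "known", "first", "only" and "open" are said of these compounds alone.

Compound 1 `C[n+]1cccc(OP(=O)([O-])OC[C@H]2O[C@@H](n3cc(F)c(=O)[nH]c3=O)C[C@@H]2OC(=O)c2ccccc2)c1`: 14.8 h
Compound 2 `CCCCCCCCCC[n+]1cccc(OP(=O)([O-])OC[C@H]2O[C@@H](n3cc(F)c(=O)[nH]c3=O)C[C@@H]2OC(=O)c2ccccc2)c1`: 16.5 h

These two half-lives come from a physicochemical assay for metabolic stability, read by HPLC, tested at 2 mM; a higher number here means that the compound lasts longer, a lower number that the compound disappears faster. Compound 2, at 16.5 h, cannot be told apart from compound 1, at 14.8 h, since the gap between them lies within the scatter of repeated measurements.

Compound 3 `O=C(O[C@H]1C[C@H](n2cc(F)c(=O)[nH]c2=O)O[C@@H]1COP(=O)([O-])Oc1ccc[n+](Cc2ccccc2)c1)c1ccccc1` has not yet been measured. It keeps the shared core of compound 2 and changes one group: phenyl in place of nonyl on a saturated chain carbon bound to an aromatic nitrogen. In words, this is phenyl in place of nonyl on a saturated chain carbon bound to an aromatic nitrogen, which can also be read as decyl to benzyl.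

Within the data shown here, only one measured step bears on this change, and it concerns the same place: a 1.1-fold higher number from compound 1 to compound 2 (0.05 log units; within the scatter). That step put nonyl in place of hydrogen and left the half-life within the scatter. It is thin evidence, since no group with a ring has yet been measured at this place. Even so, no step beyond the scatter is expected in this assay.

Compound 3 is estimated at 15 h, with an expected range from 9 h to 25 h. This estimate means a 1.1-fold lower number from compound 2 to compound 3 (0.04 log units; within the scatter).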

Compound 3, half-life: 10.8 h
Beside the measured number, compound 3's estimate is 1.4-fold (0.14 log units) above it, within the range that was stated.
By their numbers in this assay, from the lowest: compounds 3, 1 and 2 (each within the scatter of the next).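

In this assay, among these compounds, this is the first group with a ring at this place on a saturated chain carbon bound to an aromatic nitrogen, and exchanging nonyl for phenyl gives a 1.5-fold lower number from compound 2 to compound 3 (0.18 log units; within the scatter). Phenyl in place of hydrogen at the same carbon gives a 1.4-fold lower number from compound 1 to compound 3 (0.14 log units; within the scatter), so all three compounds now sit within the scatter of one another, and the ring adds something the earlier pair could not show: at this place, neither a long open chain nor a six-membered aromatic ring gives a step that can be told apart from repeated measurement. Nothing measured here accounts for these small differences.

Nonyl and phenyl both have carbon as their only heavy atoms, so it remains open whether an amine or a carboxylic acid carried on this same chain carbon would also stay within the scatter. All three compounds also keep the shared core, which leaves open how the half-life would respond to a change elsewhere in the molecule.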